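Amide to Urea: What to Expect for Compound 4

The compounds below may be only part of what the source reports. "The series", "measured", "known", "first", "only" and "open" are said of these compounds alone.

Three compounds were measured in a functional assay on Hs-578T cells (Homo sapiens) for inhibition, read by sulforhodamine B assay, with a stated time of 48 h; on this read-out higher numbers stand for weaker inhibition of growth and lower numbers for stronger inhibition of growth.
Compound 1 `O=C(Nc1cccc(-n2cc(-c3ccncc3)c(-c3ccc(Cl)c(O)c3)n2)c1)Nc1ccc(Cl)c(Cl)c1` gives 3150 nM.
Compound 2 `COc1cc(-c2nn(-c3cccc(NC(=O)c4ccc(Cl)c(C(F)(F)F)c4)c3)cc2-c2ccncc2)ccc1Cl` gives > 32500 nM, which is a limit of the assay rather than a number.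
Compound 3 `COc1cc(-c2nn(-c3cccc(NC(=O)c4cccc(C(F)(F)F)c4)c3)cc2-c2ccncc2)ccc1Cl` gives > 50000 nM, again a limit of the assay and not a number.

Compound 3 therefore stands only at a limit (the limit of > 50000 nM in this assay, at which 1 of the 3 values shown sits), and compound 2 stands at a limit as well (the limit of > 32500 nM in this assay, at which 1 of the 3 values shown sits), so the step that the two limits leave unreadable from compound 2 to compound 3 cannot be read in size or direction. The unmeasured compound 4 `COc1cc(-c2nn(-c3cccc(NC(=O)Nc4cccc(C(F)(F)F)c4)c3)cc2-c2ccncc2)ccc1Cl` differs from compound 3 by (3-(trifluoromethyl)phenyl)amino in place of 3-(trifluoromethyl)phenyl on a carbonyl carbon. Among the measured compounds shown here, no measured step covers this change. Compound 1 also carries a urea and gives 3150 nM in this assay, but it differs from compound 4 in more than one place, so it only shows that a urea in this series can reach a measurable number. Compound 4 is estimated at 20000 nM, with a range from 4000 nM to 100000 nM. The expected step of an at least 2.5-fold lower number from compound 3 to compound 4 (0.39 log units; beyond the scatter) is uncertain, since it starts from a limit.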

Compound 4, concentration for total growth inhibition: 12500 nM
Beside the measured number, compound 4's estimate is 1.6-fold (0.20 log units) above it; low and high end bracket the measured number.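

In this assay, placing (3-(trifluoromethyl)phenyl)amino on the carbonyl carbon in place of 3-(trifluoromethyl)phenyl turns the amide into a urea and gives an at least 4.0-fold lower number from compound 3 to compound 4 (0.60 log units; beyond the scatter), so this change on the shared core now has a readable direction towards stronger inhibition of growth. The same kind of exchange, starting from 4-chloro-3-(trifluoromethyl)phenyl, gives an at least 2.6-fold lower number from compound 2 to compound 4 (0.41 log units; beyond the scatter), although this step also removes the chloro group. Both sizes are minimums, since each starting amide stands at a limit of the assay and not at a number.

The compounds shown leave open how far the gain depends on the nitrogen itself, which a carbamate, with an oxygen in that place, could test. They also leave open whether a chloro group on the outer ring of the urea of compound 4 would change its value.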